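The source may report more compounds than this note shows. Statements on the series, on what has been measured and on what is new or still open speak of the compounds shown alone.

Three sulfones built on the same core were examined in an ADME assay on microsomes from liver (Homo sapiens) for metabolic stability, tested at 2.5 uM; on this read-out higher numbers stand for fast clearance and lower numbers for slow clearance. Compound 1 `COc1ccc(-c2c(S(=O)(=O)c3cccc(F)c3)cnc3cc(F)ccc23)cc1` gives 1.89 mL/min in this assay. Compound 2 `COc1cccc(-c2c(S(=O)(=O)c3cc(F)cc(F)c3)cnc3cc(F)ccc23)c1` gives 1.81 mL/min, and compound 3 `COc1ccc(S(=O)(=O)c2cnc3cc(F)ccc3c2-c2cccc(Cl)c2)cc1Cl` gives 1.19 mL/min. The three numbers lie within the usual scatter of one another, so none of the compounds can be set apart from the others on this read-out, and compound 1 simply sits among them.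

Compound 4 `COc1ccc(-c2c(S(=O)(=O)c3cc(Cl)cc(Cl)c3)cnc3cc(F)ccc23)cc1` has not yet been measured. Its structure departs from that of compound 1 in one place: 3,5-dichlorophenyl in place of 3-fluorophenyl on a sulfonyl sulfur. Among the measured compounds shown here, no measured pair in this set shows this particular change, so there is no direct precedent to lean on. Since the three measured compounds, which carry different halogenated aryl groups on the sulfonyl sulfur, all fall within the scatter of one another, the step from compound 1 to compound 4 is expected to be small, a 1.1-fold lower number from compound 1 to compound 4 (0.05 log units; within the scatter), with no confident direction. Compound 4 is therefore estimated to give 1.7 mL/min in this assay, with a range from 0.9 mL/min to 3.2 mL/min.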

Compound 4, intrinsic clearance in a liver preparation (reported as CLH), per the amount of preparation that the assay uses: 1 mL/min
The estimate for compound 4 lay 1.7-fold (0.23 log units) above the measured number, within the range that was stated.
By their numbers in this assay, from the lowest: compounds 4, 3, 2 and 1 (each within the scatter of the next).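

This first direct pair at the position gives, in this assay, a 1.9-fold lower number from compound 1 to compound 4 (0.28 log units; within the scatter), so the step is still not separable from repeat-measurement noise. Among the compounds shown here, on a sulfonyl sulfur whose other neighbour is an aromatic carbon, 3,5-dichlorophenyl in place of 3-fluorophenyl therefore leaves the clearance read-out without a change that can be claimed, which the earlier compounds could only suggest indirectly, as none of them formed a pair differing in this one place. Nothing available here bears on the reason for this outcome.

Since this is a single pair, the compounds shown leave open whether the same swap would behave alike with a different aryl group on the shared core. They also leave open how an amine or a carboxylic acid on the sulfonyl aryl ring would compare with these halogens.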